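A few compounds are considered here, and "the series" means these few. Any claim that something is new, unique, unknown or untested is made for them only; others in the source may bear on it.

Measured so far: compound 1 `O=c1cc(/C=N\Nc2ccccc2)c2ccc(OCc3ccccc3)cc2o1` with 416000 nM in a functional assay, read by spectrophotometry, with a stated time of 5 min (on this read-out lower numbers stand for stronger inhibition and higher numbers for weaker inhibition), and compound 2 `O=c1cc(/C=N\Nc2ccc([N+](=O)[O-])cc2)c2c(OCc3ccccc3)cc(OCc3ccccc3)cc2o1` with 419000 nM in the same assay.

Compound 2 holds the highest of the two numbers, but its nearest neighbour, compound 1, sits at a gap that lies within the scatter, so the two cannot be told apart. Compound 3 `O=c1cc(/C=N\Nc2ccccc2)c2c(OCc3ccccc3)cc(OCc3ccccc3)cc2o1` is the unmeasured partner of compound 2; the change is hydrogen in place of nitro on an aromatic carbon, a hydrogen in place of nitro on an aromatic carbon. Both known compounds lack or carry the nitro without any separation, so the step from compound 2 to compound 3 is expected to be small, roughly none beyond the scatter: a 1.0-fold lower number from compound 2 to compound 3 (0.02 log units; within the scatter). Compound 3 is expected to give about 400000 nM, between 150000 nM and 1000000 nM.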

Compound 3, half-maximal inhibitory concentration: 303000 nM
Compound 3: middle estimate off by 1.3-fold (0.12 log units), on the high side, and the stated range covers the measured number.
By their numbers in this assay, from the lowest: compounds 3, 1 and 2 (each within the scatter of the next).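

In this assay, hydrogen in place of nitro on the aromatic carbon para to a large group gives a 1.4-fold lower number from compound 2 to compound 3 (0.14 log units; within the scatter) and so leaves the phenyl and 4-nitrophenyl forms indistinguishable at this position. Benzyloxy in place of hydrogen on an aromatic carbon of the shared core gives a 1.4-fold lower number from compound 1 to compound 3 (0.14 log units; within the scatter) and likewise does not separate that pair. Nothing available explains these results. As far as these compounds go, whether an amine or a carboxylic acid at the nitro position would stand apart from hydrogen remains open. So does the outcome of a methoxy in place of either benzyloxy group.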